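Replacing the amine side chain of compound 1 with a thiophenylsulfanyl

The source may report more compounds than this note shows. Statements on the series, on what has been measured and on what is new or still open speak of the compounds shown alone.

Measured compounds:
- compound 1, `CN(CCC#N)C[C@H]1CN(c2ccc(-n3cc(-c4ccccn4)cn3)c(F)c2)C(=O)O1`: > 400 ug/mL
- compound 2, `COC(=O)CC1CCN(C[C@H]2CN(c3ccc(-n4cc(-c5ccccn5)cn4)c(F)c3)C(=O)O2)CC1`: > 400 ug/mL
- compound 3, `O=C1CNC(=O)N1C[C@H]1CN(c2ccc(-n3cc(-c4ccccn4)cn3)c(F)c2)C(=O)O1`: > 400 ug/mL

All three share one core and are tested in an ADME assay on L02 cells (Homo sapiens) for cytotoxicity, read by MTT assay, with a stated time of 48 h; a lower number here means a stronger inhibitor, a higher number a weaker inhibitor. For compound 1 the value of > 400 ug/mL is a limit of the assay, not a number. The value of compound 2 is likewise a limit. The value of compound 3 is a limit as well. Where compound 1 stands among the three therefore cannot be said more closely: all values sit together at the limit of > 400 ug/mL in this assay, at which 3 of the 3 values shown sit, and the steps a step that the two limits leave unreadable from compound 1 to compound 2, a step that the two limits leave unreadable from compound 1 to compound 3 and a step that the two limits leave unreadable from compound 2 to compound 3 are unreadable in size.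

Compound 4, `O=C1O[C@@H](CSc2cccs2)CN1c1ccc(-n2cc(-c3ccccn3)cn2)c(F)c1`, differs from compound 1 by (thiophen-2-yl)sulfanyl in place of (2-cyanoethyl)(methyl)amino on a saturated chain carbon bound to a saturated ring carbon. Among the measured compounds shown here, the measured steps all alter the same saturated chain carbon, and none of them moved the read-out off the limit, so they offer no step of readable size pointing in either direction in this assay. Compound 4 is therefore expected to show a step of a number no higher from compound 1 to compound 4 (the limit leaves the size open). The value of compound 4 is estimated at 400 ug/mL, between 150 ug/mL and 800 ug/mL.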

Compound 4, half-maximal inhibitory concentration: > 400 ug/mL
Compound 4 ended at the assay's limit; the forecaster's own chance of this, stated with the estimate: 65%; the middle value sits exactly at the limit.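

Like compound 1, compound 2 and compound 3, compound 4 gives a limit and not a number, so the size of the steps to compound 4 cannot be read: the limit of > 400 ug/mL in this assay, at which 4 of the 4 values shown sit.

The compounds shown leave open the true value of each compound in this assay, and whether these side chains differ at all.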